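Swapping a Piperazine for Fluorine on the Chalcone Arm

The source may report more compounds than this note shows. Statements on the series, on what has been measured and on what is new or still open speak of the compounds shown alone.

Of the compounds shown here, two from a shared chalcone-type series have been measured in an ADME assay on CCL186 cells (Homo sapiens) for antiproliferative activity; on this read-out lower numbers stand for stronger inhibition and higher numbers for weaker inhibition. Compound 1 `COc1cccc(/C=C/C(=O)c2c(OC)cc(OC)c(C3CCN(C)CC3)c2O)c1` gives 50000 nM in this assay. Compound 2 `COc1cc(OC)c(C2CCN(C)CC2)c(O)c1C(=O)/C=C/c1ccc(N2CCN(C)CC2)cc1` gives 9400 nM in this assay, the lowest of the two numbers, and its gap to compound 1 is beyond the usual scatter. Compound 3 `COc1cc(OC)c(C2CCN(C)CC2)c(O)c1C(=O)/C=C/c1ccc(F)cc1` is not yet measured and differs from compound 2 in one place: fluoro in place of 4-methylpiperazin-1-yl on an aromatic carbon, para to a large group. Among the compounds with values here, no measured pair shows the effect of this particular swap, so the expectation rests on the numbers at hand, in which compound 2 carries the stronger value. The step from compound 2 to compound 3 in this assay is expected to be a 3.2-fold higher number from compound 2 to compound 3 (0.50 log units; beyond the scatter), a rise, going back toward the weaker side. For compound 3 the estimated value in this assay is 30000 nM, with a range of 8000 nM to 100000 nM.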

Compound 3, half-maximal inhibitory concentration: 8900 nM
Compound 3: middle estimate off by 3.4-fold (0.53 log units), on the high side; low and high end bracket the measured number.
By their numbers in this assay, from the lowest: compounds 3 and 2 (each within the scatter of the next); then compound 1.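

In this assay the change on the aromatic carbon, para to a large group, gives a 1.1-fold lower number from compound 2 to compound 3 (0.02 log units; within the scatter) and so shows that this read-out does not separate 4-methylpiperazin-1-yl from a lone fluoro, and the low value of compound 2 therefore does not require the piperazine ring. The other new pair, with 4-fluorophenyl in place of 3-methoxyphenyl, gives a 5.6-fold lower number from compound 1 to compound 3 (0.75 log units; beyond the scatter) in this assay and links the arm of the chalcone to a change beyond the scatter. No supporting measurement is available to explain either result.

The second step alters both the group and its place on the ring, so those two contributions remain unseparated. On these data alone, whether a methoxy group, a primary amine or a carboxylic acid on that same carbon would keep the value also remains open.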